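Benzylsulfonyl Hydroxamate Weighed Against Its Aryl Relatives

This account rests on a few compounds, and the source may have more. Where it says the series, first, only, none or still open, it means among the compounds named here.

Measured compounds:
- Compound 1 `O=C(CCCC1CCN(S(=O)(=O)c2ccccc2Cl)CC1)NO`: in a functional assay on HCT-116 cells (Homo sapiens) for inhibition, read by resazurin assay, with a stated time of 5 days (a higher number here means a weaker inhibitor of growth, a lower number a stronger inhibitor of growth), compound 1 gives 2800 nM.
- Compound 2 `O=C(CCCC1CCN(S(=O)(=O)c2cccc(Cl)c2)CC1)NO`: in this assay compound 2 gives "not determined" (no result reported).
- Compound 3 `COc1cccc(S(=O)(=O)N2CCC(CCCC(=O)NO)CC2)c1`: in this assay compound 3 gives "not determined" (no result reported).

Three hydroxamates share the same core, a piperidine-bearing hydroxamic acid carrying a sulfonyl group on the ring nitrogen, and differ only in what sits on the sulfonyl sulfur. Only compound 1 has a number in this assay. Among the compounds with values here, compound 3 stands without any figure there, as does compound 2, so no comparison among the measured three can be made and no step between measured compounds is available.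

Compound 4 `O=C(CCCC1CCN(S(=O)(=O)Cc2ccccc2)CC1)NO` is the untested member. Relative to compound 3 it carries benzyl in place of 3-methoxyphenyl on a sulfonyl sulfur. Within the data shown here, with no measured step to lean on, the account can only take the single figure of compound 1 in this assay as the reference point for this series, and no shift beyond the usual scatter is expected from the change to the benzyl group.

Compound 4 is expected to give 3000 nM in this assay, within a range of 700 nM to 13000 nM.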

Compound 4, concentration for 50% growth inhibition: 3200 nM
Beside the measured number, compound 4's estimate is 1.1-fold (0.03 log units) below it; the measured number falls inside the stated range.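

In this assay, within the data shown here, the step of a 1.1-fold higher number from compound 1 to compound 4 (0.06 log units; within the scatter) gives the first reading of a change on the sulfonyl sulfur, with benzyl in place of 2-chlorophenyl. It shows that this place tolerates a benzyl group as well as a 2-chlorophenyl group in this one pair, and that the aromatic ring need not stand directly on the sulfur for growth inhibition to stay at this level. No measured evidence bears on this result.

Going by these compounds, the steps involving compound 2 and compound 3 cannot be read; neither compound has a result in this assay, and so the effect of replacing 3-methoxyphenyl with benzyl remains unknown. Also open, on these data alone, is how a phenethyl group, a plain methyl group, or a carboxylic acid on the benzyl group would read at this place.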